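Shortening a Long Chain on a Pyrone-Derived Core

This account rests on a few compounds, and the source may have more. Where it says the series, first, only, none or still open, it means among the compounds named here.

The compounds here share one core and differ in the chain attached to it. Compound 1 `CCCCCCCCCCCCCCNC(=O)c1c(O)cc(C)oc1=O` carries a long chain through an amide-type nitrogen. In an ADME assay on L929 cells (Mus musculus, culture collection number NCTC 929) for cytotoxicity, read by MTT assay, with a stated time of 72 h (a higher number here means a weaker inhibitor, a lower number a stronger inhibitor), compound 1 gives > 200000 nM, which is a limit of the assay and not a number, as noted in the limit of > 200000 nM in this assay, at which 1 of the 3 values shown sits. Compound 3 `CCCCCCNC(=O)c1c(O)cc(C)oc1=O` has a shorter chain, and in this assay compound 3 gives 196000 nM. The change between them is hydrogen in place of octyl on a saturated chain carbon, six bonds along the chain from an amide-type nitrogen, and the step is an at least 1.0-fold lower number from compound 1 to compound 3 (0.00 log units; that floor lies within the scatter).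

Compound 2 `CCCCCCCCCCCCCCCC(=O)c1c(O)cc(C)oc1=O` joins its long chain to the core through a carbonyl carbon instead; how its core differs from that of compound 1 is not broken down here. In this assay compound 2 gives 165000 nM.

Compound 4 `CCCCCCCC(=O)c1c(O)cc(C)oc1=O` is not yet measured. Its change from compound 2 is hydrogen in place of octyl on a saturated chain carbon, seven bonds along the chain from a carbonyl carbon, the same kind of change as from compound 1 to compound 3, though the place differs: six bonds along the chain from an amide-type nitrogen there, seven bonds along the chain from a carbonyl carbon here. Resting on compound 3 and an at least 1.0-fold lower number from compound 1 to compound 3 (0.00 log units; that floor lies within the scatter), the expected step is a 1.1-fold higher number from compound 2 to compound 4 (0.04 log units; within the scatter). Compound 4 is thus estimated at 180000 nM in this assay, between 90000 nM and 350000 nM.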

Compound 4, half-maximal inhibitory concentration: 140000 nM
For compound 4 the middle estimate is 1.3-fold (0.11 log units) above the measured one; the range from low to high includes it.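

Hydrogen in place of octyl on a saturated chain carbon, seven bonds along the chain from a carbonyl carbon, gives a 1.2-fold lower number from compound 2 to compound 4 (0.07 log units; within the scatter) in this assay, so on the core of compound 2 this change moves the number no further than the scatter. Set beside the same change on the core of compound 1, the two steps can be compared only in part: the same change on two cores in this assay, an at least 1.0-fold lower number (0.00 log units; that floor lies within the scatter) from compound 1 to compound 3 and a 1.2-fold lower number (0.07 log units; within the scatter) from compound 2 to compound 4; the limit leaves it open whether they differ. In this assay compound 1 gives > 200000 nM, a limit of the assay and not a number, so the series shows neither that the change carries over from one core to the other with the same size nor that it does not.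

The compounds shown leave open what other groups in place of octyl would do on either core, such as an amine, a carboxylic acid or a longer chain. They also leave open whether any such group would give a step beyond the scatter.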